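This account rests on a few compounds, and the source may have more. Where it says the series, first, only, none or still open, it means among the compounds named here.

Measured compounds:
compound 1, `Nc1ncnn2c([C@@H]3O[C@H](CO)[C@@H](O)[C@H]3O)cc(C#Cc3cccs3)c12`: in a functional assay on Z-138 cells (Homo sapiens) for antiproliferative activity, with a stated time of 72 h (a higher number here means a weaker inhibitor, a lower number a stronger inhibitor), compound 1 gives 50100 nM
compound 2, `Nc1ncnn2c([C@@H]3O[C@H](CO)[C@@H](O)[C@H]3O)cc(-c3ccc(F)cc3)c12`: in this assay compound 2 gives only a limit, > 100000 nM

Compound 2 sits at the assay floor, (the limit of > 100000 nM in this assay, at which 1 of the 2 values shown sits), so no number is known for it. Going by the values given here, the only measured step is an at least 1.9-fold higher number from compound 1 to compound 2 (0.30 log units; that floor lies within the scatter), and its floor lies within the scatter. Compound 3, `Nc1ncnn2c([C@@H]3O[C@H](CO)[C@@H](O)[C@H]3O)cc(-c3ccccc3Cl)c12`, differs from compound 2 by 2-chlorophenyl in place of 4-fluorophenyl on an aromatic carbon. Among the compounds with values here, no measured step exchanges 4-fluorophenyl for 2-chlorophenyl, so no shift beyond the scatter is expected in this assay. Compound 3 is estimated at 100000 nM, range 30000 nM to 300000 nM. The expected step is a number no higher from compound 2 to compound 3 (the limit leaves the size open), with a fair chance that only a limit is again returned.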

Compound 3, half-maximal inhibitory concentration: 76100 nM
Compound 3: the middle estimate sits 1.3-fold (0.12 log units) above what was measured; low and high end bracket the measured number.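

Compound 3 shows that an aryl group on this aromatic carbon can return a number in this assay. Replacing 2-(thiophen-2-yl)ethynyl with 2-chlorophenyl gives a 1.5-fold higher number from compound 1 to compound 3 (0.18 log units; within the scatter), so these two groups are not separated here. Exchanging 4-fluorophenyl for 2-chlorophenyl gives an at least 1.3-fold lower number from compound 2 to compound 3 (0.11 log units; that floor lies within the scatter), and this can be read only as a floor, as compound 2 gives only a limit: the limit of > 100000 nM in this assay, at which 1 of the 3 values shown sits.

From the compounds shown here alone, whether 4-fluorophenyl and 2-chlorophenyl truly differ remains open. Also open, going by these compounds, is how 4-chlorophenyl, or a phenyl ring carrying an amine or a carboxylic acid, would behave at this position.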